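Removing the isopropyl from the ring amide nitrogen

The compounds below may be only part of what the source reports. "The series", "measured", "known", "first", "only" and "open" are said of these compounds alone.

The series shares the core seen in compound 1 `COc1ccc(N2C(=O)COc3ccc(-c4ccc(O)cc4)cc32)cc1`, compound 2 `COc1ncc(-c2ccc3c(c2)N(C2CCCCC2)C(=O)CO3)cc1NS(=O)(=O)c1ccc(F)cc1` and compound 3 `CC(C)N1C(=O)COc2ccc(-c3cccc(NS(=O)(=O)c4ccc(F)cc4)c3)cc21`, each tested in a functional assay on A549 cells (Homo sapiens) for antiproliferative activity, read by MTT assay, with a stated time of 72 h; on this read-out lower numbers stand for stronger inhibition and higher numbers for weaker inhibition. Compound 1 reaches only a limit in this assay, namely > 40000 nM. Compound 2 gives 24600 nM in this assay, while compound 3 gives 29400 nM; these two numbers sit within the scatter of each other, so no order between them can be read. Compound 4 `O=C1COc2ccc(-c3cccc(NS(=O)(=O)c4ccc(F)cc4)c3)cc2N1` differs from compound 3 by hydrogen in place of isopropyl on an amide-type nitrogen in a ring. Going by the values given here, no measured pair isolates this change, so its effect is uncertain; a step toward a somewhat higher number, or none beyond the scatter, is expected, a 1.2-fold higher number from compound 3 to compound 4 (0.08 log units; within the scatter). Compound 4 is therefore expected to give about 35000 nM in this assay, with a range from 15000 nM to 80000 nM.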

Compound 4, half-maximal inhibitory concentration: 32100 nM
For compound 4 the middle estimate is 1.1-fold (0.04 log units) above the measured one; the measured number falls inside the stated range.
By their numbers in this assay, from the lowest: compounds 2, 3 and 4 (each within the scatter of the next). At a limit, above all of these: compound 1.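

In this assay, going by these compounds alone, hydrogen in place of isopropyl on the amide-type nitrogen in the ring gives a 1.1-fold higher number from compound 3 to compound 4 (0.04 log units; within the scatter) and is the first measured pair at this position. Within this high range of numbers, the isopropyl is not needed to hold the value of compound 3. Compound 1 stands at a limit of the read-out: the limit of > 40000 nM in this assay, at which 1 of the 4 values shown sits.

Open, going by these compounds, is whether a larger group on this nitrogen, such as a longer chain ending in an amine or a carboxylic acid, moves the number beyond the scatter. On these data alone, whether the same step holds on a series with lower numbers also remains open.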